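This account rests on a few compounds, and the source may have more. Where it says the series, first, only, none or still open, it means among the compounds named here.

Of the compounds shown here, three have been tested in an ADME assay on L1210/0 cells (Mus musculus) for cytotoxicity, with a stated time of 48 h; a lower number here means a stronger inhibitor, a higher number a weaker inhibitor. Compound 1 `OC[C@@H]1C[C@H](Cn2cnc3c(NC4CCC4)ncnc32)c2c(-c3ccccc3)nnc(-c3ccccc3)c21` gives 90800 nM in this assay. Compound 2 `COc1ccc(C(=O)/C=C/c2cc(=O)[nH]c(=O)n2COCCO)cc1` gives 33500 nM. Compound 3 `C=Cc1cn([C@H]2C[C@H](O)[C@@H](CO)O2)c(=O)[nH]c1=O` gives 14200 nM, the lowest number of the three, with compound 2 nearest and compound 1 furthest away, both gaps beyond the scatter.

Compound 4 `CCC#Cc1cn([C@H]2C[C@H](O)[C@@H](CO)O2)c(=O)[nH]c1=O` differs from compound 3 in a single place: but-1-yn-1-yl in place of vinyl on an aromatic carbon. For the measured compounds named here, no measured pair shows what this kind of change does here, so the expectation rests only on compound 3 and its value 14200 nM. A small step is expected, with the number for compound 4 drifting somewhat higher, though it may stay within the scatter. The estimate for compound 4 is 22000 nM, within a range from 5000 nM to 100000 nM.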

Compound 4, half-maximal inhibitory concentration: > 200000 nM
Compound 4 was reported as a limit; the forecaster's own chance of this, stated with the estimate: 10%; at least 9.0-fold (0.95 log units) between middle value and limit.
By their numbers in this assay, from the lowest: compound 3; then compound 2; then compound 1. At a limit, above all of these: compound 4.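

For the compounds shown here, this is the first pair to differ in one place, and it shows that this aromatic carbon is sensitive in this assay: but-1-yn-1-yl in place of vinyl gives an at least 14-fold higher number from compound 3 to compound 4 (1.14 log units; beyond the scatter). The value for compound 4 is a limit, the only one among the compounds shown: the limit of > 200000 nM in this assay, at which 1 of the 4 values shown sits. A single swap of one small carbon group is therefore enough to take the number out of the measured range.

This pair changes chain length and bond type together, so the two cannot be told apart. As far as these compounds go, what an ethynyl group, a butyl chain or an amine would do on this carbon stays open.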